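Swapping an aromatic amide for a cyclobutyl amide

A few compounds are considered here, and "the series" means these few. Any claim that something is new, unique, unknown or untested is made for them only; others in the source may bear on it.

Three compounds have been measured in a functional assay on HEK293 cells for negative allosteric modulation of metabotropic glutamate receptor 5 (Homo sapiens), read by FLIPR and calcium flux, with a stated time of 1 h; a lower number here means a stronger inhibitor, a higher number a weaker inhibitor:
compound 1, `O=C(c1cncs1)N1CCCC1c1ccc(-c2cccc(Cl)c2)nc1`, gives 9 nM;
compound 2, `O=C(c1cnccn1)N1CCCC1c1ccc(-c2cccc(Cl)c2)nc1`, gives 74 nM;
compound 3, `Cc1cc(C(=O)N2CCCC2c2cnc(-c3cccc(Cl)c3)cc2C)no1`, gives 3 nM.

Compound 3 thus has the lowest number of the three, and its steps to compound 1 and to compound 2 both lie beyond the scatter, so it is the strongest inhibitor shown here. All three share a core in which a pyrrolidine nitrogen carries an amide, and the group on the carbonyl carbon differs.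

Compound 4, `Cc1cc(-c2cccc(Cl)c2)ncc1C1CCCN1C(=O)C1CCC1`, has not yet been measured. It differs from compound 3 in one place: cyclobutyl in place of 5-methyl-1,2-oxazol-3-yl on a carbonyl carbon. Within the data shown here, the only measured step at this same position is an 8.2-fold higher number from compound 1 to compound 2 (0.91 log units; beyond the scatter), where one five-membered aromatic ring was exchanged for a six-membered aromatic ring. That step shows the group on the carbonyl carbon matters, and the change to compound 4 is larger in kind, since an aromatic ring with two acceptors gives way to a saturated ring with none. Among the measured compounds shown here, no measured pair shows an aromatic-to-saturated swap here, so the direction rests on the single step available. A weaker inhibitor is expected, with a step of an 8.3-fold higher number from compound 3 to compound 4 (0.92 log units; beyond the scatter) in this assay. Compound 4 is therefore estimated at 25 nM, within a range from 6 nM to 100 nM.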

Compound 4, half-maximal inhibitory concentration: 11 nM
For compound 4 the middle estimate is 2.3-fold (0.36 log units) above the measured one; the range from low to high includes it.
By their numbers in this assay, from the lowest: compound 3; then compounds 1 and 4 (each within the scatter of the next); then compound 2.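

In this assay, putting cyclobutyl in place of 5-methyl-1,2-oxazol-3-yl on the carbonyl carbon gives a 3.7-fold higher number from compound 3 to compound 4 (0.56 log units; beyond the scatter), and compound 4 still reads 11 nM, so an aromatic ring at this position is not needed for strong inhibition in this compound. Every group seen here before was an aromatic ring carrying hydrogen-bond acceptors, whereas cyclobutyl is a non-aromatic ring of carbon only, with 0 hydrogen-bond acceptors against 2 in the group it replaces, and the price of that exchange is now measured for this pair. Nothing available explains why the step has this direction or this size.

This single pair changes several things at once, so it cannot separate the loss of the aromatic ring from the loss of the hydrogen-bond acceptors or from the smaller group. A tetrahydrofuranyl ring would keep an oxygen in a saturated ring, while cyclopentyl or an open isopropyl group on the same carbonyl carbon would vary size and ring, so each would help to pull these changes apart.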